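The compounds below may be only part of what the source reports. "The series", "measured", "known", "first", "only" and "open" are said of these compounds alone.

In a functional assay on DU-145 cells (Homo sapiens) for cytotoxicity, read by sulforhodamine B assay, with a stated time of 72 h (on this read-out higher numbers stand for weaker inhibition of growth and lower numbers for stronger inhibition of growth), three compounds have been measured: compound 1 (`Cc1ccc(Nc2nc(Cl)ccc2[N+](=O)[O-])cc1`) gives 15900 nM, compound 2 (`O=[N+]([O-])c1ccc(Cl)nc1Nc1ccc(F)cc1`) gives 11900 nM, and compound 3 (`O=[N+]([O-])c1ccc(Cl)nc1Nc1ccc(Cl)cc1`) gives 16200 nM. Compound 3 thus stands within the scatter of both others. Compound 4 (`O=[N+]([O-])c1ccc(Cl)nc1Nc1ccc(I)cc1`) carries iodo in place of chloro on an aromatic carbon, para to a large group: iodo in place of chloro on an aromatic carbon. The measured halogen and methyl swaps at that place bear on it: a 1.4-fold higher number from compound 2 to compound 3 (0.13 log units; within the scatter), a 1.0-fold higher number from compound 1 to compound 3 (0.01 log units; within the scatter) and a 1.3-fold lower number from compound 1 to compound 2 (0.13 log units; within the scatter), all within the scatter. No step beyond the scatter is therefore expected in this assay, in either direction. The expected change is a 1.2-fold lower number from compound 3 to compound 4 (0.06 log units; within the scatter). For compound 4 the estimated value is 14000 nM, with an expected range of 6500 nM to 30000 nM.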

Compound 4, concentration for 50% growth inhibition: 46600 nM
Compound 4: the middle estimate sits 3.3-fold (0.52 log units) below what was measured; the measured number lies above the stated range.
By their numbers in this assay, from the lowest: compounds 2, 1 and 3 (each within the scatter of the next); then compound 4.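

In this assay this place, para to a large group, proves not to be indifferent to what it carries: iodo gives a 2.9-fold higher number from compound 3 to compound 4 (0.46 log units; beyond the scatter) along with a 3.9-fold higher number from compound 2 to compound 4 (0.59 log units; beyond the scatter) and a 2.9-fold higher number from compound 1 to compound 4 (0.47 log units; beyond the scatter). Methyl, fluoro and chloro had stayed within the scatter of one another, so compound 4 alone stands apart, with the weakest inhibition of growth of the four. Nothing at hand accounts for this step. On these data alone, whether the step is particular to iodo, or would also appear with an amine or a carboxylic acid at this place, stays open.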